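This account rests on a few compounds, and the source may have more. Where it says the series, first, only, none or still open, it means among the compounds named here.

Compounds measured:
compound 1, `CC(=O)O[C@H]1C=CC(=O)O[C@@H]1c1nc(/C=C/c2ccccc2)oc1-c1ccccc1`, 24600 nM
compound 2, `CC(=O)O[C@H]1C=CC(=O)O[C@@H]1[C@@H](O)[C@@H](Nc1ccccc1)c1ccccc1`, a limit of > 40000 nM
compound 3, `CC(=O)O[C@H]1C=CC(=O)O[C@H]1[C@H]1OC(C)(C)O[C@@H]1c1ccccc1`, a limit of > 40000 nM

The read-out is a functional assay on SMMC-7721 cells (Homo sapiens) for cytotoxicity, read by MTT assay, with a stated time of 48 h; on this read-out lower numbers stand for stronger inhibition and higher numbers for weaker inhibition. Going by the values given here, compound 1 gives the only number in this assay, 24600 nM. Compound 2 reaches only a limit, > 40000 nM. Compound 3 likewise reaches only a limit, > 40000 nM. Among the compounds with values here, two of the three measured compounds therefore sit at the limit of > 40000 nM in this assay, at which 2 of the 3 values shown sit, and compound 1 stands as the one compound with a defined value, at a weak level of inhibition.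

Compound 4, `C/C=C\c1nc([C@H]2OC(=O)C=C[C@@H]2OC(C)=O)c(-c2ccccc2)o1`, differs from compound 1 in one place: prop-1-en-1-yl in place of 2-phenylethenyl on an aromatic carbon. Within the data shown here, no measured pair shows a step of this kind, so the size of the change cannot be read from the numbers at hand. On the evidence of compound 1 alone, he expects the step in this assay from compound 1 to compound 4 to be modest and, if anything, toward weaker inhibition, a 1.4-fold higher number from compound 1 to compound 4 (0.15 log units; within the scatter). For compound 4 he therefore estimates 35000 nM, with a range from 15000 nM to 80000 nM, and he notes that this assay may report only a limit for compound 4 instead of a number.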

Compound 4, half-maximal inhibitory concentration: > 40000 nM
Compound 4: a limit, no number; the forecaster's own chance of this, stated with the estimate: 40%; at least 1.1-fold (0.05 log units) between middle value and limit.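

In this assay, going by these compounds alone, replacing 2-phenylethenyl with prop-1-en-1-yl on the aromatic carbon gives the only step available at this position: an at least 1.6-fold higher number from compound 1 to compound 4 (0.21 log units; that floor lies within the scatter). Compound 4 reaches only a limit, so this step is a floor and not a measured size, and that floor lies within the scatter, which means the result does not establish a real loss of inhibition. Within the data shown here, what it does add is that the smaller prop-1-en-1-yl group, which lacks the six-membered aromatic ring of 2-phenylethenyl, does not bring a defined value at this position, and compound 1 remains the only compound with a number: the limit of > 40000 nM in this assay, at which 3 of the 4 values shown sit.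

The compounds shown leave open whether any other group on this aromatic carbon would give a defined value, for instance a longer chain ending in a phenyl group, an amine or a carboxylic acid. On these data alone, they also leave open how far compound 4 lies past its limit, so the true size of the step from the 2-phenylethenyl compound remains unknown.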